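The source may hold more compounds than are shown below. What is called first, only, known or untested is meant among the compounds shown, and "the series" means these compounds.

Compound 1, `CN(C)c1cccc(Oc2ccc3c(NCCCNCc4ccco4)ccnc3c2)c1`: 317 10^-6 cm/s
Compound 2, `COc1cccc(CNCCCNc2ccnc3cc(Cc4ccc(F)cc4)ccc23)c1O`: 23 10^-6 cm/s
Compound 3, `COc1cccc(CNCCCNc2ccnc3cc(CCC(C)C)ccc23)c1O`: 23 10^-6 cm/s

In an ADME assay for permeability, using PAMPA, with a stated time of 30 min, at pH 7.4 (on this read-out lower numbers stand for lower permeability and higher numbers for higher permeability), compound 3 gives 23 10^-6 cm/s, level with compound 2, and together these two are the lowest of the three numbers. Compound 1 gives a higher number, a gap well beyond the scatter. Compound 4, `COc1cccc(CNCCCNc2ccnc3cc(Oc4cccc(N(C)C)c4)ccc23)c1O`, has not yet been measured; it differs from compound 3 by 3-(dimethylamino)phenoxy in place of isopentyl on an aromatic carbon. Among the measured compounds shown here, one measured step bears on this change: no change at the digits printed from compound 2 to compound 3 (within the scatter), which shows that exchanging the group at the same place on the shared core, while keeping the chain end, left the number unchanged. For the measured compounds named here, compound 1 carries the same 3-(dimethylamino)phenoxy group as compound 4 but a different chain end, so its high value cannot be split between the two changes, and no single step links it to compound 4. As compounds 2 and 3 share their chain end with compound 4 and agree despite carrying different groups at that place, compound 4 is expected to move only modestly upward from compound 3, by a 1.3-fold higher number from compound 3 to compound 4 (0.12 log units; within the scatter), a step within the scatter. The estimate for compound 4 in this assay is 30 10^-6 cm/s, with a range from 12 10^-6 cm/s to 90 10^-6 cm/s.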

Compound 4, apparent permeability: 317 10^-6 cm/s
Estimate against measurement, compound 4: 11-fold (1.02 log units) below; the measured number lies above the stated range.
By their numbers in this assay, from the lowest: compounds 2 and 3 (each within the scatter of the next); then compounds 1 and 4 (each within the scatter of the next).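

In this assay, the aromatic carbon that carries the variable group on the shared core proves able to shift the number, although the exchange between compound 2 and compound 3 had left it flat. Putting 3-(dimethylamino)phenoxy in place of isopentyl gives a 14-fold higher number from compound 3 to compound 4 (1.14 log units; beyond the scatter), and putting it in place of 4-fluorobenzyl gives a 14-fold higher number from compound 2 to compound 4 (1.14 log units; beyond the scatter), so the two earlier groups matching each other did not mean that every group at this place would read the same. With 3-(dimethylamino)phenoxy in place, the chain end also separates from the result, since 2-hydroxy-3-methoxyphenyl in place of furan-2-yl gives no change at the digits printed from compound 1 to compound 4 (within the scatter), and nothing reported here accounts for the size of the step at the aromatic carbon.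

The compounds shown leave open which part of the entering group goes with the higher number, the ether oxygen, the aromatic ring or the dimethylamino group, and an unsubstituted phenoxy or a 3-(dimethylamino)benzyl group at this place would separate these parts. They also leave open whether the furan-2-yl chain end would read as low as the 2-hydroxy-3-methoxyphenyl one when paired with isopentyl.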